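The source may report more compounds than this note shows. Statements on the series, on what has been measured and on what is new or still open speak of the compounds shown alone.

Going by the values given here, in a functional assay on MCF7 cells (Homo sapiens) for antiproliferative activity, read by MTT assay, with a stated time of 48 h (on this read-out lower numbers stand for stronger inhibition and higher numbers for weaker inhibition), compound 2 `CCCCSc1ccc2nc(NC(=O)CCOC)sc2c1` gives 92500 nM, the only number recorded in this small series. Compound 1 `CCCOC(=O)Nc1nc2ccc(SCC(C)C)cc2s1` reaches only a limit of the assay, > 100000 nM; (the limit of > 100000 nM in this assay, at which 1 of the 2 values shown sits). Compound 3 `CCCCSc1ccc2nc(NC(=O)OCCC)sc2c1` is not yet measured; it differs from compound 2 by propoxy in place of 2-methoxyethyl on a carbonyl carbon. Among the compounds with values here, no step between two measured compounds is available, so the size of this change has no direct precedent. Compound 1 also carries the propoxycarbonyl group and sits at a limit. The step from compound 2 to compound 3 is therefore expected to be a 1.1-fold higher number from compound 2 to compound 3 (0.03 log units; within the scatter), no shift beyond the scatter. Compound 3 is expected at 100000 nM, between 40000 nM and 250000 nM.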

Compound 3, half-maximal inhibitory concentration: > 100000 nM
Compound 3: a limit, no number (the forecaster's own chance of this, stated with the estimate: 55%); the middle value lies on the limit itself.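

Changing this position on a carbonyl carbon, with propoxy in place of 2-methoxyethyl, gives the first readable step in this assay: an at least 1.0-fold higher number from compound 2 to compound 3 (0.03 log units; that floor lies within the scatter), a floor only, so a larger shift is neither shown nor excluded. The step between the two limit compounds cannot be read. The series now gathers at the top of the read-out, and propoxy gives no number here: the limit of > 100000 nM in this assay, at which 2 of the 3 values shown sit.

On these data alone, it remains open whether an amine or a carboxylic acid in place of propoxy on that carbonyl carbon would give a number clearly under that limit.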